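This account rests on a few compounds, and the source may have more. Where it says the series, first, only, none or still open, it means among the compounds named here.

Compound 1 `Cc1ccccc1S(=O)(=O)Nc1ccc2oc(-c3ccccc3)nc2c1` and compound 2 `COc1ccccc1S(=O)(=O)Nc1ccc2oc(-c3ccccc3)nc2c1` share one core and differ in a single substituent on the ring that carries the sulfonyl group. In an assay on isolated protein for inhibition of malate dehydrogenase, mitochondrial (Sus scrofa), with stated times of 45 min and 30 min (on this read-out lower numbers stand for stronger inhibition and higher numbers for weaker inhibition), compound 1 gives > 63000 nM, which is a limit of the assay and not a number. In this assay compound 2 likewise gives > 63000 nM, again a limit rather than a number. The step that the two limits leave unreadable from compound 1 to compound 2 is therefore unreadable, since both ends sit at limits. Within the data shown here, compound 2 thus stands at a limit, and the one other value shown is a limit too, both of them sitting at the limit of > 63000 nM in this assay, at which 2 of the 2 values shown sit. Compound 3 `COc1ccc(Cl)cc1S(=O)(=O)Nc1ccc2oc(-c3ccccc3)nc2c1` differs from compound 2 by chloro in place of hydrogen on an aromatic carbon, a chloro in place of hydrogen on an aromatic carbon, meta to a large group and para to a methoxy group. No measured step bears on this change, because the only step shown, from compound 1 to compound 2, runs between two limits. The expected step that the limit leaves unreadable from compound 2 to compound 3 is accordingly none beyond the scatter. Compound 3 is estimated at 100000 nM in this assay, within 15000 nM to 600000 nM, most likely again reported only as a limit.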

Compound 3, half-maximal inhibitory concentration: > 63000 nM
Compound 3: no number, only a limit; the forecaster's own chance of this, stated with the estimate: 80%; the middle value does not contradict the limit.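

In this assay, among these compounds, compound 3 gives > 63000 nM which is again a limit of the assay and not a number, so no step linking compound 3 to compound 1 or compound 2 can be read. The compounds shown leave open whether methoxy or chloro on this ring alters inhibition at all, as all three stand at one limit: the limit of > 63000 nM in this assay, at which 3 of the 3 values shown sit.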